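The source may hold more compounds than are shown below. What is called first, only, known or untested is meant among the compounds shown, and "the series" means these compounds.

Measured so far in a functional assay on CCRF-CEM cells (Homo sapiens) for inhibition, read by sulforhodamine B assay, with a stated time of 48 h; on this read-out lower numbers stand for stronger inhibition of growth and higher numbers for weaker inhibition of growth:
compound 1 `O=C(Cc1csc2nc(-c3ccc(Br)cc3)cn12)N/N=C/c1ccccc1` gives 17400 nM
compound 2 `O=C(Cc1csc2nc(-c3ccc(Br)cc3)cn12)N/N=C/c1ccc(O)cc1` gives 12300 nM
compound 3 `COc1cccc(OC)c1/C=N/NC(=O)Cc1csc2nc(-c3ccc(Br)cc3)cn12` gives 9550 nM

Compound 3 is not separated from the other two: a 1.8-fold lower number from compound 1 to compound 3 (0.26 log units; within the scatter) and a 1.3-fold lower number from compound 2 to compound 3 (0.11 log units; within the scatter) both stay within the scatter, as does a 1.4-fold lower number from compound 1 to compound 2 (0.15 log units; within the scatter) among the remaining pair. The unmeasured compound 4 `O=C(Cc1csc2nc(-c3ccc(Br)cc3)cn12)N/N=C/c1ccc(Cl)cc1Cl` has 2,4-dichlorophenyl in place of 2,6-dimethoxyphenyl on a carbon with a double bond to nitrogen as its change. Going by the values given here, these three steps are the only guide, and no measured compound carries chlorine. In this assay the expectation is therefore no step beyond the scatter, in either direction. The estimated outcome is a 1.0-fold higher number from compound 3 to compound 4 (0.02 log units; within the scatter) and nothing larger. The estimate for compound 4 is 10000 nM with 4000 nM to 25000 nM as its expected range.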

Compound 4, concentration for 50% growth inhibition: 39800 nM
The estimate for compound 4 lay 4.0-fold (0.60 log units) below the measured number; the whole stated range lies below it.
By their numbers in this assay, from the lowest: compounds 3, 2 and 1 (each within the scatter of the next); then compound 4.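

In this assay the group on the carbon with a double bond to nitrogen now separates compounds: 2,4-dichlorophenyl gives a 4.2-fold higher number from compound 3 to compound 4 (0.62 log units; beyond the scatter) and a 3.2-fold higher number from compound 2 to compound 4 (0.51 log units; beyond the scatter) and a 2.3-fold higher number from compound 1 to compound 4 (0.36 log units; beyond the scatter) while phenyl, 4-hydroxyphenyl and 2,6-dimethoxyphenyl remain within the scatter of one another. Going by these compounds alone, this place is therefore not indifferent to its group, and the one separated change goes toward weaker inhibition of growth. Nothing available explains this shift. Open, from the compounds shown here alone, is whether a single chlorine, an amine or a carboxylic acid on this phenyl ring would move the number, and in which direction.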